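One Group Swap on Two Cores: Estimating Compound 4

A few compounds are considered here, and "the series" means these few. Any claim that something is new, unique, unknown or untested is made for them only; others in the source may bear on it.

Compound 1 `Cn1cc(C(=O)N2CC3(C2)CN(c2cncc(N4C(=O)c5ccc(Cl)cc5C4(C)C)c2)C3)cn1` gives 2 nM in an assay on cells for inhibition of cytochrome P450 11B2, mitochondrial (Homo sapiens), read by HTRF; a lower number here means a stronger inhibitor, a higher number a weaker inhibitor.
Compound 2 `CCS(=O)(=O)N1CC(Oc2cncc(N3C(=O)c4ccc(Cl)cc4C3(C)C)c2)C1` gives 4 nM in this assay.
Compound 3 `Cn1cc(C(=O)N2CC(Oc3cncc(N4C(=O)c5ccc(Cl)cc5C4(C)C)c3)C2)cn1` gives 0.5 nM in this assay.

Compound 3 and compound 2 share one core and differ in a single place: ethylsulfonyl in place of (1-methyl-1H-pyrazol-4-yl)carbonyl on an amine nitrogen in a ring. That exchange made the number go up, an 8.0-fold higher number from compound 3 to compound 2 (0.90 log units; beyond the scatter), so the ethylsulfonyl version is the weaker inhibitor of the pair.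

Compound 1 carries the (1-methyl-1H-pyrazol-4-yl)carbonyl group on a different core, a four-membered non-aromatic ring with 1 nitrogen joined to another ring at one shared atom; how this core differs from that of compound 3 is not broken down here. Compound 4 `CCS(=O)(=O)N1CC2(CN(c3cncc(N4C(=O)c5ccc(Cl)cc5C4(C)C)c3)C2)C1` has not yet been measured. It is related to compound 1 by the same kind of change: ethylsulfonyl in place of (1-methyl-1H-pyrazol-4-yl)carbonyl on an amine nitrogen in a ring. The surroundings differ, since in compound 1 the ring atom bearing the group sits in a system of two rings, whereas in compound 3 it bears a large group on a single ring.

The expectation for compound 4 rests on compound 1 and the step already seen: the number is expected to rise by a 7.0-fold higher number from compound 1 to compound 4 (0.85 log units; beyond the scatter), roughly matching an 8.0-fold higher number from compound 3 to compound 2 (0.90 log units; beyond the scatter). Compound 4 is therefore estimated at 14 nM, likely between 5 nM and 45 nM.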

Compound 4, half-maximal inhibitory concentration: 16 nM
Beside the measured number, compound 4's estimate is 1.1-fold (0.06 log units) below it; low and high end bracket the measured number.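

In this assay, putting ethylsulfonyl in place of (1-methyl-1H-pyrazol-4-yl)carbonyl on the core of compound 1 gives an 8.0-fold higher number from compound 1 to compound 4 (0.90 log units; beyond the scatter), so the ethylsulfonyl version is again the weaker inhibitor of its pair. The size of the step carries over from one core to the other: the same change on two cores in this assay, an 8.0-fold higher number (0.90 log units; beyond the scatter) from compound 3 to compound 2 and an 8.0-fold higher number (0.90 log units; beyond the scatter) from compound 1 to compound 4, 1.0-fold (0.00 log units) apart, within the scatter of two such steps
Going by these compounds alone, this rests on only two matched pairs, so it shows that the exchange behaves alike on these two cores, but it does not show that it would do so on any other core, and it does not explain why ethylsulfonyl gives the higher number.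

The compounds shown leave open how other groups on that amine nitrogen in a ring would compare, such as a shorter methylsulfonyl, a simple acetyl or a longer propylsulfonyl chain, and whether these would also track across the two cores. They also leave open whether the step seen in this assay would appear in any other measurement.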